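The source may report more compounds than this note shows. Statements on the series, on what has been measured and on what is new or still open speak of the compounds shown alone.

In a physicochemical assay for lipophilicity, read by HPLC (on this read-out higher numbers stand for higher lipophilicity and lower numbers for lower lipophilicity), compound 1 `CCn1c(-c2cnc(C)nc2)nc2c(O[C@H]3CCN(C(=O)C4CC4)C3)ncnc21` gives 1. Compound 2 `CCn1c(-c2cnc(C)nc2)nc2c(O[C@H]3CCN(C(=O)C4CCOC4)C3)ncnc21` gives 0.7, and the step of a number 0.30 log units lower from compound 1 to compound 2 (within the scatter) leaves the two numbers within the scatter of each other. The next change leads to compound 3 `CCn1c(-c2cnc(C)nc2)nc2c(O[C@H]3CCN(C(=O)[C@H]4C[C@@H](OC)C4)C3)ncnc21`: 3-methoxycyclobutyl in place of oxolan-3-yl on a carbonyl carbon. Among the measured compounds shown here, only the step from compound 1 to compound 2 concerns a group on the same carbonyl carbon, and it stayed within the scatter, so no step beyond the scatter is expected in this assay. Compound 3 is estimated at 1, between 0.6 and 1.4. The expected step reads a number 0.30 log units higher from compound 2 to compound 3 (within the scatter).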

Compound 3, distribution coefficient: 1
Beside the measured number, compound 3's estimate shows no gap at the digits printed; the range from low to high includes it.
By their numbers in this assay, from the lowest: compounds 2, 1 and 3 (each within the scatter of the next).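

In this assay, 3-methoxycyclobutyl in place of oxolan-3-yl on the carbonyl carbon gives a number 0.30 log units higher from compound 2 to compound 3 (within the scatter), and 3-methoxycyclobutyl in place of cyclopropyl gives no change at the digits printed from compound 1 to compound 3 (within the scatter). All three groups on this carbonyl carbon, including the larger 3-methoxycyclobutyl with its four-membered carbon ring, therefore lie within the scatter of one another in this assay. Nothing at hand explains this result. Still open, going by these compounds, is how an amine, a carboxylic acid or a longer chain on this carbonyl carbon would read, and whether the other stereoisomer of 3-methoxycyclobutyl would also stay within the scatter.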